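Methyl to ethyl: the untested step from compound 2

The source may hold more compounds than are shown below. What is called first, only, known or untested is meant among the compounds shown, and "the series" means these compounds.

- compound 1 `COc1cccc(OS(=O)(=O)c2ccc(N3CCN(C)C3=O)cc2)c1` gives 2500 nM
- compound 2 `COc1cc(OC)cc(OS(=O)(=O)c2ccc(N3CCN(C)C3=O)cc2)c1` gives 190 nM
- compound 3 `COc1cc(OS(=O)(=O)c2ccc(N3CCN(C)C3=O)cc2)cc(OC)c1OC` gives 62 nM

All three values come from a functional assay on HT-29 cells (Homo sapiens) for antiproliferative activity, read by sulforhodamine B assay, with a stated time of 48 h (on this read-out higher numbers stand for weaker inhibition and lower numbers for stronger inhibition), where compound 2 holds the second highest of the three numbers, with compound 3 lower and compound 1 higher. The next compound to be tested is compound 4 `CCN1CCN(c2ccc(S(=O)(=O)Oc3cc(OC)cc(OC)c3)cc2)C1=O` which differs from compound 2 in one place. The change is methyl in place of hydrogen on a saturated chain carbon bound to an amide-type nitrogen in a ring and amounts to methyl in place of hydrogen on a saturated chain carbon bound to an amide-type nitrogen in a ring, turning 3-methyl-2-oxoimidazolidin-1-yl into 3-ethyl-2-oxoimidazolidin-1-yl.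

Both measured steps are methoxy in place of hydrogen on an aromatic carbon, one large (a 13-fold lower number from compound 1 to compound 2 (1.12 log units; beyond the scatter)) and one modest (a 3.1-fold lower number from compound 2 to compound 3 (0.49 log units; beyond the scatter)). Neither touches the place that changes in compound 4, so they show how far these compounds move in this assay but give no direction for the new change. Within the data shown here, no measured compound carries the ethyl group, which leaves compound 2 (190 nM) as the anchor. No step beyond the scatter is expected (a 1.1-fold higher number from compound 2 to compound 4 (0.02 log units; within the scatter)). Compound 4 is therefore estimated at 200 nM (expected range 70 nM to 600 nM).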

Compound 4, half-maximal inhibitory concentration: 4300 nM
Estimate against measurement, compound 4: 22-fold (1.33 log units) below, outside the stated range (above it).
By their numbers in this assay, from the lowest: compound 3; then compound 2; then compounds 1 and 4 (each within the scatter of the next).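

In this assay, the saturated chain carbon bound to an amide-type nitrogen in a ring proves to be a sensitive place: a single added methyl, turning 3-methyl-2-oxoimidazolidin-1-yl into 3-ethyl-2-oxoimidazolidin-1-yl, gives a 23-fold higher number from compound 2 to compound 4 (1.35 log units; beyond the scatter). Until now, the compounds had moved only through methoxy in place of hydrogen on an aromatic carbon, and only toward lower numbers, so this is the first step shown in the direction of weaker inhibition, and it belongs to the same large class as a 13-fold lower number from compound 1 to compound 2 (1.12 log units; beyond the scatter). There is no measurement here that accounts for this loss of activity at the new position.

The compounds shown leave open whether the loss is particular to the ethyl group or continues with a longer chain such as propyl, and whether a branched group such as isopropyl, a cyclopropyl ring or a hydroxyethyl chain would behave in the same way. They also leave open whether the ethyl group would cost as much on the core of compound 3, which carries the additional methoxy group, as it does on the core of compound 2.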